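Piperazine amide series: benzyl extension at the ring nitrogen

A few compounds are considered here, and "the series" means these few. Any claim that something is new, unique, unknown or untested is made for them only; others in the source may bear on it.

In a functional assay on HT-29 cells (Homo sapiens) for cytotoxicity, read by MTT assay, with a stated time of 24 h, tested at 16 ug/mL (on this read-out lower numbers stand for a weaker effect and higher numbers for a stronger effect at the one concentration tested), the measured members of the series read as follows.
compound 1 `Cn1c(-c2ccc(NC(=O)CSc3nc4ccccc4s3)cc2)nc(-c2ccccc2)c1-c1ccccc1`: compound 1 gives 47.2%
compound 2 `Cn1nnnc1SCC(=O)Nc1ccc(-c2nc(-c3ccccc3)c(-c3ccccc3)n2C)cc1`: compound 2 gives 72.5%
compound 3 `CN1CCN(CC(=O)Nc2ccc(-c3nc(-c4ccccc4)c(-c4ccccc4)n3C)cc2)CC1`: compound 3 gives 33.7%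

Compound 3 stands lowest of the three in this assay, and both steps leading to it are beyond the scatter: a number 13.5 percentage points lower from compound 1 to compound 3 (beyond the scatter) and a number 38.8 percentage points lower from compound 2 to compound 3 (beyond the scatter). The remaining step among the measured compounds, a number 25.3 percentage points higher from compound 1 to compound 2 (beyond the scatter), runs in the other direction. All three steps exchange the whole group on the saturated chain carbon bound to the carbonyl carbon; none alters anything within the 4-methylpiperazin-1-yl group once it is present.

Compound 4 `Cn1c(-c2ccc(NC(=O)CN3CCN(Cc4ccccc4)CC3)cc2)nc(-c2ccccc2)c1-c1ccccc1` is the next member, not yet measured. The change from compound 3 is phenyl in place of hydrogen on a saturated chain carbon bound to an amine nitrogen in a ring. Among the compounds with values here, no measured step bears directly on this place: the steps that involve compound 3 bring the whole ring in or take it out, so they do not show what a change at the saturated chain carbon bound to the amine nitrogen in the ring does. With no guide of that kind, the expectation for compound 4 is a step within the scatter, a number 4.3 percentage points higher from compound 3 to compound 4 (within the scatter). Compound 4 is therefore estimated at 38%, in the range 20% to 58%.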

Compound 4, a percentage reported as activity, at one concentration (the size of the read-out at that concentration, not a potency): 37%
Estimate against measurement, compound 4: 1 percentage points above; low and high end bracket the measured number.
By their numbers in this assay, from the lowest: compounds 3 and 4 (each within the scatter of the next); then compound 1; then compound 2.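

In this assay, within the data shown here, phenyl in place of hydrogen on a saturated chain carbon bound to an amine nitrogen in a ring, the same difference as methyl to benzyl, comes with a number 3.3 percentage points higher from compound 3 to compound 4 (within the scatter) and gives the first reading of a change made within the 4-methylpiperazin-1-yl group rather than an exchange of the whole group. At this single concentration, the added six-membered aromatic ring of carbon only leaves compound 4 indistinguishable from compound 3, so the position accepts this extension with no effect that can be told from the usual variation in the read-out. Nothing available gives a reason for this outcome or connects it to any measured property of the compounds.

Still open, on these data alone, is whether any other group at this place would produce a step beyond the scatter, for example a longer chain carrying the phenyl, a carboxylic acid on the phenyl, or an amine on it. A single pair also leaves open whether the same exchange of methyl to benzyl would read the same way at another concentration of this cytotoxicity test.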